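Amide in place of ester: expectation for compound 4

The source may report more compounds than this note shows. Statements on the series, on what has been measured and on what is new or still open speak of the compounds shown alone.

Measured so far in an assay on HEK293 cells for binding affinity to Substance-K receptor (Rattus norvegicus), read by FRET, tested at 10 uM; on this read-out higher numbers stand for more inhibition at the one concentration tested (going by the name of the read-out) and lower numbers for less inhibition:
- compound 1 `CCOC(=O)CCCCN(Cc1ccccc1)Cc1ccc2ccccc2c1`: 0%
- compound 2 `O=C(O)CCCCN(Cc1ccccc1)Cc1ccc2ccccc2c1`: 0%
- compound 3 `O=C(CN(Cc1ccccc1)Cc1ccc2ccccc2c1)OCCc1ccccc1`: 0%

All three measured compounds share one core and differ only at the chain ending in the carbonyl group. Among the compounds with values here, the single step between compounds that differ in one place, hydrogen in place of ethyl on an oxygen next to a carbonyl group, gives no change at the digits printed from compound 1 to compound 2 (within the scatter). Compound 3 stands level with compounds 1 and 2 at the digits shown; its nearest neighbour is compound 1 and its furthest is compound 2, and neither gap exceeds the scatter.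

Compound 4 `CCCCNC(=O)CN(Cc1ccccc1)Cc1ccc2ccccc2c1` is not yet measured. It differs from compound 3 by butylamino in place of phenethyloxy on a carbonyl carbon. Within the data shown here, no measured step exchanges the ester oxygen for a nitrogen; the only step on the carbonyl side is the one from compound 1 to compound 2, which stayed within the scatter. On that basis the expected step in this assay is no change at the digits printed from compound 3 to compound 4 (within the scatter), none beyond the scatter. Compound 4 is therefore estimated at 0%, with a range from -10% to 15%.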

Compound 4, a percentage reported as inhibition, at one concentration (the size of the read-out at that concentration, not a potency): 0%
The estimate for compound 4 equals the measured number at the digits printed, and the stated range covers the measured number.
By their numbers in this assay, from the lowest: compounds 1, 2, 3 and 4 (each within the scatter of the next).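

In this assay the amide, butylamino in place of phenethyloxy on a carbonyl carbon, gives no change at the digits printed from compound 3 to compound 4 (within the scatter), so a hydrogen-bond donor entering and the six-membered aromatic ring leaving together do not move the read-out. Against the longer chains, butylcarbamoyl gives no change at the digits printed from compound 2 to compound 4 (within the scatter) and no change at the digits printed from compound 1 to compound 4 (within the scatter), so the amide, the carboxylic acid and the ethyl ester do not separate at this concentration. No supporting evidence bears on this result.

The exchange between compound 3 and compound 4 alters the linking atom and the ring at once, and phenethylamino on the same carbonyl carbon would separate the two. As far as these compounds go, with all four compounds level, it remains open whether any other group on this chain, such as a terminal amine or a piperidine amide, gives inhibition in this assay at all.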